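The source may report more compounds than this note shows. Statements on the series, on what has been measured and on what is new or still open speak of the compounds shown alone.

Compound 2 `Cc1nc(NCCCNS(C)(=O)=O)nc2ccc(NC(=O)/C=C/c3ccc(OC(F)(F)F)cc3)cc12` gives 32 nM in a functional assay on CHO-K1 cells for antagonist activity at melanin-concentrating hormone receptor 1 (Homo sapiens), read by inositol phosphate accumulation, with stated times of 10 min and 45 min; on this read-out higher numbers stand for weaker inhibition and lower numbers for stronger inhibition. On the two numbers at hand, compound 2 and compound 1 `Cc1nc(N2CCC(N3CCOC3=O)CC2)nc2ccc(NC(=O)/C=C/c3ccc(OC(F)(F)F)cc3)cc12` lie within the scatter of each other, compound 1 giving 31 nM in this assay. Among the compounds with values here, the single measured step, a 1.0-fold higher number from compound 1 to compound 2 (0.01 log units; within the scatter), exchanged a ring-bearing group for an open chain without moving the number. Compound 3 `Cc1nc(NCCNS(C)(=O)=O)nc2ccc(NC(=O)/C=C/c3ccc(OC(F)(F)F)cc3)cc12` differs from compound 2 by a shorter chain: methanesulfonamido in place of (methanesulfonamido)methyl on a saturated chain carbon, two bonds along the chain from a nitrogen on an aromatic ring. Within the data shown here, no measured step shortens this chain, so the only guide is that this region tolerated a large swap. The expected step is a 1.3-fold higher number from compound 2 to compound 3 (0.10 log units; within the scatter). Compound 3 is estimated at 40 nM, within 15 nM to 120 nM.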

Compound 3, half-maximal inhibitory concentration: 142 nM
Beside the measured number, compound 3's estimate is 3.6-fold (0.55 log units) below it, and the stated range ends below it.
By their numbers in this assay, from the lowest: compounds 1 and 2 (each within the scatter of the next); then compound 3.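

Shortening 3-(methanesulfonamido)propyl to 2-(methanesulfonamido)ethyl gave a 4.4-fold higher number from compound 2 to compound 3 (0.65 log units; beyond the scatter), so this position, which had seemed indifferent, does respond to chain length. The shorter chain also gives weaker inhibition than the ring-bearing group of compound 1, with a 4.6-fold higher number from compound 1 to compound 3 (0.66 log units; beyond the scatter). A change of one chain carbon therefore counted here, while the much larger swap from compound 1 to compound 2 did not. Nothing available explains this difference. From the compounds shown here alone, whether a longer chain, such as 4-(methanesulfonamido)butyl, would hold or improve the number stays open, as does the effect of an amine or a carboxylic acid in place of the methanesulfonamido end.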